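Dichloro in place of fluoro on the biaryl ring

The source may hold more compounds than are shown below. What is called first, only, known or untested is meant among the compounds shown, and "the series" means these compounds.

Two compounds with a shared core carry different groups on the pendant aromatic ring. Compound 1 `Clc1ccc(-c2ccc3nc(Cl)nc(N[C@@H]4C[C@H]5CC[C@@H]4C5)c3c2)cc1` gives 208 nM in a functional assay for positive allosteric modulation of GABA-B receptor (Homo sapiens), read by GTPgammaS binding; a higher number here means that more compound is needed for the effect, a lower number that less compound is needed. Compound 2 `Fc1ccc(-c2ccc3nc(Cl)nc(N[C@@H]4C[C@H]5CC[C@@H]4C5)c3c2)cc1` gives 294 nM in this assay, the highest of the two numbers, with compound 1 nearest; the step of a 1.4-fold higher number from compound 1 to compound 2 (0.15 log units; within the scatter) lies within the scatter. Compound 3 `Clc1nc(N[C@@H]2C[C@H]3CC[C@@H]2C3)c2cc(-c3ccc(Cl)c(Cl)c3)ccc2n1` differs from compound 2 by 3,4-dichlorophenyl in place of 4-fluorophenyl on an aromatic carbon. Among the measured compounds shown here, the only measured step that bears on this change is the exchange of fluoro for chloro between compound 1 and compound 2, which stayed within the scatter, so a return to chloro at the same position is expected to bring the number back toward that of compound 1, while nothing measured here tells what the second chloro adds. Compound 3 is therefore expected to show a step of a 1.7-fold lower number from compound 2 to compound 3 (0.24 log units; within the scatter) in this assay, giving an estimate of 170 nM with a range from 70 nM to 420 nM.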

Compound 3, half-maximal effective concentration: 341 nM
For compound 3 the middle estimate is 2.0-fold (0.30 log units) below the measured one; the measured number falls inside the stated range.
By their numbers in this assay, from the lowest: compounds 1, 2 and 3 (each within the scatter of the next).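

The earlier compounds shown here showed only one halogen exchanged for another on the pendant ring. Compound 3 adds a further substituent, and in this assay the addition of chloro in place of hydrogen gives a 1.6-fold higher number from compound 1 to compound 3 (0.21 log units; within the scatter) while the full change from 4-fluorophenyl to 3,4-dichlorophenyl gives a 1.2-fold higher number from compound 2 to compound 3 (0.06 log units; within the scatter) and so neither step leaves the scatter. Across these three compounds, then, the pendant ring carries one or two halogens with no separable difference in the number, and no supporting evidence bears on this result.

From the compounds shown here alone, whether any group other than a halogen on this ring would move the number beyond the scatter remains open, for example a methoxy group, a nitrile or an amine. Also open, going by these compounds, is how a 3-chlorophenyl group alone, or pyridyl in place of phenyl, would compare.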